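The source may hold more compounds than are shown below. What is called first, only, known or untested is meant among the compounds shown, and "the series" means these compounds.

Compound 1, `O=C(O)c1ccccc1-c1ccc(CCc2ncc(CC3CCCCC3)[nH]2)cc1`, gives 41 nM in an in vitro functional assay on cells for agonist activity at Bombesin receptor subtype-3 (Homo sapiens), read by luminescence and calcium flux; a lower number here means that less compound is needed, a higher number that more compound is needed for the effect. Compound 2, `Cc1ccccc1Cc1cnc(CCc2ccc(-c3ccccc3C(=O)O)cc2)[nH]1`, gives 127 nM in this assay. Among the measured compounds shown here, the one change between them, 2-methylphenyl in place of cyclohexyl on a saturated chain carbon bound to an aromatic carbon, brings a 3.1-fold higher number from compound 1 to compound 2 (0.49 log units; beyond the scatter). Among the two measured compounds, compound 2 therefore carries the higher number, and its only neighbour is compound 1.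

Compound 3, `N#Cc1ccccc1Cc1cnc(CCc2ccc(-c3ccccc3C(=O)O)cc2)[nH]1`, differs from compound 2 in one place: cyano in place of methyl on an aromatic carbon. For the measured compounds named here, the single measured step bears on a different part of the shared core, so it says little about swapping methyl for cyano on that aromatic carbon. With nothing measured that speaks directly to this change, compound 3 is expected to stay within the scatter of compound 2, a step of a 1.0-fold higher number from compound 2 to compound 3 (0.01 log units; within the scatter), and its value is estimated at 130 nM, with a likely range from 50 nM to 350 nM.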

Compound 3, half-maximal effective concentration: 5480 nM
Compound 3: middle estimate off by 42-fold (1.62 log units), on the low side; the whole stated range lies below it.
By their numbers in this assay, from the lowest: compound 1; then compound 2; then compound 3.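

In this assay, among the compounds shown here, the group on this aromatic carbon, ortho to a large group, proves to matter far more than the earlier compounds could show: cyano in place of methyl brings a 43-fold higher number from compound 2 to compound 3 (1.63 log units; beyond the scatter). That step is much larger than the earlier change of cyclohexyl to 2-methylphenyl, and replacing cyclohexyl with 2-cyanophenyl gives a 130-fold higher number from compound 1 to compound 3 (2.13 log units; beyond the scatter). Nothing available explains why this one small swap has so large an effect.

With only methyl and cyano shown here, it remains open whether methyl is especially favourable or cyano especially unfavourable. A chlorine, a methoxy group or a plain hydrogen on the same carbon could help separate these two readings, and could show how narrow the tolerance at this position really is.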